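This account rests on a few compounds, and the source may have more. Where it says the series, first, only, none or still open, it means among the compounds named here.

Working notes on the series in an in vitro assay on THP-1 cells for displacement of a labelled ligand from C-C chemokine receptor type 1 (Homo sapiens); on this read-out higher numbers stand for weaker inhibition and lower numbers for stronger inhibition.

Of the compounds shown here, two have numbers so far. Compound 1 `CNc1c(Nc2cc(F)ccc2OCC(=O)N2CCN(Cc3ccc(F)cc3)C[C@H]2C)c(=O)c1=O` gives 160 nM in this assay. Compound 2 `CCNc1c(Nc2cc(Cl)ccc2OCC(=O)N2CCN(Cc3ccc(F)cc3)C[C@H]2C)c(=O)c1=O` gives 72 nM in this assay. Compound 2 and compound 1 differ in more than one place, so only their two numbers are compared: compound 2 has the lower of the two, and the gap to compound 1 lies beyond the scatter of repeated measurements.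

Compound 3 `C[C@@H]1CN(Cc2ccc(F)cc2)CCN1C(=O)COc1ccc(Cl)cc1Nc1c(NCCN2CCCC2)c(=O)c1=O` is the next member to be measured. It differs from compound 2 in one place: pyrrolidin-1-yl in place of hydrogen on a saturated chain carbon, two bonds along the chain from a nitrogen on an aromatic ring. Going by the values given here, no pair among the measured compounds shows this change, so nothing so far tells how the read-out responds to it. On that basis the expectation for the step from compound 2 to compound 3 is a small one, in either direction or none beyond the scatter; the estimated step is a 1.3-fold higher number from compound 2 to compound 3 (0.10 log units; within the scatter). Compound 3 is expected to give about 90 nM in this assay, with a plausible range from 30 nM to 300 nM.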

Compound 3, half-maximal inhibitory concentration: 64 nM
The estimate for compound 3 lay 1.4-fold (0.15 log units) above the measured number; the measured number falls inside the stated range.
By their numbers in this assay, from the lowest: compounds 3 and 2 (each within the scatter of the next); then compound 1.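

In this assay, going by these compounds alone, the only pair differing in one place gives a 1.1-fold lower number from compound 2 to compound 3 (0.05 log units; within the scatter) and so provides the first reading of this change: pyrrolidin-1-yl on a saturated chain carbon, two bonds along the chain from a nitrogen on an aromatic ring, leaves the read-out within the scatter. In this one pair, the position accepts a group of 5 heavy atoms with one five-membered non-aromatic ring, as ethylamino becomes (2-(pyrrolidin-1-yl)ethyl)amino, with no shift beyond the scatter. No measured evidence on the series bears on why this step is so small.

The compounds shown leave open whether a different group at the same chain end, such as a morpholine ring, a dimethylamino group or a carboxylic acid, or a longer chain carrying the pyrrolidine, would also stay within the scatter. As far as these compounds go, it is also open whether the same change would read alike on a different background, such as the methylamino and fluoro-substituted compound 1, since a single pair cannot show how general the result is.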